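Swapping Allylamino for Propoxy on a Carbonyl Carbon

The source may hold more compounds than are shown below. What is called first, only, known or untested is meant among the compounds shown, and "the series" means these compounds.

Of the compounds shown here, three have been tested in a functional assay on the whole organism for inhibition, with Brassica rapa subsp. chinensis as the target, with a stated time of 3 days, tested at 100 ppm; on this read-out higher numbers stand for more inhibition of growth at the one concentration tested and lower numbers for less inhibition of growth. Compound 1 `Cc1ccc(OC(=O)/C=C/c2ccc(Cl)cc2Cl)c(C(C)C)c1` gives 0%, compound 2 `CC(C)NC(=O)/C=C/c1ccccc1` gives 76%, and compound 3 `C=CCNC(=O)/C=C/c1ccccc1` gives 64%, which places compound 3 second highest of the three, close to compound 2 and far from compound 1. Going by the values given here, the only single-point step available, a number 12 percentage points lower from compound 2 to compound 3 (beyond the scatter), concerns the group on the amide-type nitrogen and does not touch the change now in question. Compound 4 `CCCOC(=O)/C=C/c1ccccc1` differs from compound 3 by propoxy in place of allylamino on a carbonyl carbon. Compound 1 also carries an oxygen-linked group on its carbonyl carbon, yet it differs from compound 4 in several other places, so its value is only a weak hint. Compound 4 is therefore expected to show weaker inhibition, with a number 29 percentage points lower from compound 3 to compound 4 (beyond the scatter). The estimate for compound 4 is 35%, with a range from 5% to 70%.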

Compound 4, percent growth inhibition at one concentration: 7%
Estimate against measurement, compound 4: 28 percentage points above; the measured number falls inside the stated range.
By their numbers in this assay, from the lowest: compounds 1 and 4 (each within the scatter of the next); then compound 3; then compound 2.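

In this assay the earlier step changed only the group on the nitrogen, while this change replaces the nitrogen link itself. Propoxy in place of allylamino on a carbonyl carbon gives a number 57 percentage points lower from compound 3 to compound 4 (beyond the scatter), and propoxy in place of isopropylamino gives a number 69 percentage points lower from compound 2 to compound 4 (beyond the scatter), so this position tolerates the change poorly in both pairs. Nothing measured here explains the drop. The compounds shown leave open how propylamino, which keeps the same chain but retains the nitrogen, would compare. From the compounds shown here alone, a carboxylic acid or a longer alkoxy chain on this carbonyl carbon also remains open.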